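The compounds below may be only part of what the source reports. "The series", "measured", "known", "first", "only" and "open" are said of these compounds alone.

Measured compounds:
compound 1 `CCCCCCCCn1cc(/C=C/C(=O)c2ccc(NC(=O)CN3CCN(c4ccccc4F)CC3)cc2)nn1`, 47100 nM
compound 2 `O=C(CN1CCC(Cc2ccccc2)CC1)Nc1ccc(C(=O)/C=C/c2cn(Cc3ccc(Br)cc3)nn2)cc1`, 40000 nM
compound 3 `CCCCCCCCCCn1cc(/C=C/C(=O)c2ccc(NC(=O)CN3CCN(c4ccccc4)CC3)cc2)nn1`, 52100 nM

All three were run in a functional assay on A549 cells (Homo sapiens) for inhibition, read by MTT assay; on this read-out higher numbers stand for weaker inhibition and lower numbers for stronger inhibition. Compound 2 shows the lowest of the three numbers, but its distances to compound 1 and to compound 3 both lie within the usual scatter, so no order among them can be read. Compound 1 gives 47100 nM and compound 3 gives 52100 nM, while compound 2 gives 40000 nM.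

Compound 4 `CCCCCCCCCCn1cc(/C=C/C(=O)c2ccc(NC(=O)CN3CCC(Cc4ccccc4)CC3)cc2)nn1` has not yet been measured in this assay. It differs from compound 2 in one place: nonyl in place of 4-bromophenyl on a saturated chain carbon bound to an aromatic nitrogen. Going by the values given here, no pair of measured compounds shares this single change, so no measured step can be cited for it. What the data do show is that the two compounds bearing long alkyl chains, compound 1 and compound 3, sit within the scatter of compound 2, which carries the 4-bromobenzyl group.

Compound 4 is therefore expected to show a step of a 1.2-fold higher number from compound 2 to compound 4 (0.08 log units; within the scatter), which is no change beyond the scatter, because compound 1 gives 47100 nM and compound 3 gives 52100 nM. The estimate for compound 4 in this assay is 48000 nM, with a range from 24000 nM to 96000 nM.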

Compound 4, half-maximal inhibitory concentration: 67700 nM
For compound 4 the middle estimate is 1.4-fold (0.15 log units) below the measured one; low and high end bracket the measured number.
By their numbers in this assay, from the lowest: compounds 2, 1, 3 and 4 (each within the scatter of the next).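

This position now has a single-place step in this assay: replacing the 4-bromobenzyl group with decyl gives a 1.7-fold higher number from compound 2 to compound 4 (0.23 log units; within the scatter). On this core, then, an open alkyl chain can stand in place of the bromine-bearing aromatic ring on the saturated chain carbon bound to an aromatic nitrogen, with no change that can be told from the scatter. No supporting data bear on why this is so.

From the compounds shown here alone, it remains open whether the bromine and the aromatic ring matter separately, which an unsubstituted benzyl group would test. Also open, going by these compounds, is whether a much shorter chain such as ethyl, or a decyl chain ending in a carboxylic acid or an amine, would move the number beyond the scatter.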